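From Isobutyl to Isopropyl on a Sulfonamide Nitrogen

The source may hold more compounds than are shown below. What is called first, only, known or untested is meant among the compounds shown, and "the series" means these compounds.

Compound 1 (`CC(C)CN(Cc1ccc(C(=O)NO)cc1)S(=O)(=O)c1cc(F)c(F)c(F)c1F`): 690 nM
Compound 2 (`CC(C)N(Cc1ccc(C(=O)NO)cn1)S(=O)(=O)c1cc(F)c(F)c(F)c1F`): 1600 nM
Compound 3 (`CC(C)N(Cc1ccc(C(=O)NO)cc1)C(=O)c1c(F)c(F)c(F)c(F)c1F`): 12300 nM

In a functional assay on MM1.S cells (Homo sapiens) for inhibition, with a stated time of 72 h (on this read-out lower numbers stand for stronger inhibition and higher numbers for weaker inhibition), compound 1 gives 690 nM as the lowest number of the three and is the strongest of them. Compound 2 gives 1600 nM and compound 3 gives 12300 nM in this series, and both numbers lie higher than that of compound 1 by more than the usual scatter.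

Compound 4 (`CC(C)N(Cc1ccc(C(=O)NO)cc1)S(=O)(=O)c1cc(F)c(F)c(F)c1F`) has not yet been measured. It departs from compound 1 with isopropyl in place of isobutyl on a sulfonamide nitrogen and leaves the rest of the core of compound 1 as it stands. Going by the values given here, no measured pair isolates this change, so its size cannot be read directly from the data. Compound 2 also bears isopropyl on a sulfonamide nitrogen and gives 1600 nM as a loose upper guide. A small move toward a higher number is therefore expected in this assay and probably no more than the usual scatter. The estimate is a step of a 1.3-fold higher number from compound 1 to compound 4 (0.12 log units; within the scatter) in this read-out. Compound 4 is expected at 900 nM within a range from 350 nM to 2300 nM once it is measured.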

Compound 4, half-maximal inhibitory concentration: 1380 nM
Estimate against measurement, compound 4: 1.5-fold (0.19 log units) below; measured number inside the range.
By their numbers in this assay, from the lowest: compounds 1, 4 and 2 (each within the scatter of the next, the first and the last beyond it); then compound 3.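

Going by these compounds alone, compound 1 and compound 4 form the first pair that isolates isopropyl in place of isobutyl on a sulfonamide nitrogen, since the rest of the core of compound 1 stays unchanged. In this assay this change gives a 2.0-fold higher number from compound 1 to compound 4 (0.30 log units; within the scatter), so removing one carbon from this chain, with no ring, hydrogen-bond donor, hydrogen-bond acceptor or net charge on either group, leaves the two compounds indistinguishable on this read-out. No accompanying measurement bears on how either chain acts at this position.

The compounds shown carry only isobutyl and isopropyl on this nitrogen, so it remains open whether a longer chain, a cyclopropyl ring, or a chain ending in an amine or a carboxylic acid would give a number beyond the scatter from that of compound 1. Going by these compounds, it also remains open whether isobutyl in place of isopropyl on compound 2 would give a step of similar size, so the reach of this result beyond the core of compound 1 is unknown.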